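The compounds below may be only part of what the source reports. "The series", "measured", "known", "first", "only" and "open" are said of these compounds alone.

Within the data shown here, in a functional assay on HCT-116 cells (Homo sapiens) for inhibition, read by CCK-8 assay, with a stated time of 72 h (on this read-out lower numbers stand for stronger inhibition and higher numbers for weaker inhibition), compound 2 `Nc1ccccc1NC(=O)c1ccc(CNC(=O)c2n[nH]cc2NC(=O)c2ccccc2F)cc1` gives 4800 nM, the higher of the two numbers so far. Compound 1 `O=C(NO)c1ccc(CNC(=O)c2n[nH]cc2NC(=O)c2c(Cl)cccc2Cl)cc1` gives 500 nM. That gap lies beyond the scatter, but the two compounds differ in more than one place, so it cannot be assigned to a single change. Compound 3 `O=C(NO)c1ccc(CNC(=O)c2n[nH]cc2NC(=O)c2ccccc2F)cc1` is unmeasured and departs from compound 2 in one place: hydroxy in place of 2-aminophenyl on an amide-type nitrogen. The resulting hydroxycarbamoyl is also present in compound 1, which reads 500 nM and is the only measured reference carrying that group, so the expectation rests on thin evidence. The expected change is a step of a 6.9-fold lower number from compound 2 to compound 3 (0.84 log units; beyond the scatter), toward stronger inhibition and beyond the scatter. For compound 3 the estimated value is 700 nM, with an expected range of 250 nM to 2000 nM.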

Compound 3, half-maximal inhibitory concentration: 2200 nM
Compound 3: middle estimate off by 3.1-fold (0.50 log units), on the low side; measured number outside the range, above it.
By their numbers in this assay, from the lowest: compound 1; then compound 3; then compound 2.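

In this assay, among these compounds, the first single-place reading of the change on the amide-type nitrogen, hydroxy in place of 2-aminophenyl with the 2-fluorophenyl kept, gives a 2.2-fold lower number from compound 2 to compound 3 (0.34 log units; beyond the scatter) and so favours hydroxy only modestly. With hydroxycarbamoyl held constant, 2-fluorophenyl in place of 2,6-dichlorophenyl on the carbonyl carbon gives a 4.4-fold higher number from compound 1 to compound 3 (0.64 log units; beyond the scatter), which shows that hydroxycarbamoyl alone does not set the level reached by compound 1 at 500 nM and that the group on the carbonyl carbon also shifts the number. No available evidence gives a cause for either step.

From the compounds shown here alone, whether the two changes add up remains open, as the (2-aminophenyl)carbamoyl group has been read with 2-fluorophenyl but not alongside 2,6-dichlorophenyl in a single-place pair. Also open, going by these compounds, is how an unsubstituted phenyl on the carbonyl carbon, or a carboxylic acid in place of hydroxycarbamoyl, would read.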